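Swapping methyl for fluoro on compound 2

This account rests on a few compounds, and the source may have more. Where it says the series, first, only, none or still open, it means among the compounds named here.

In a functional assay on P388 cells (Mus musculus) (a higher number here means a weaker inhibitor, a lower number a stronger inhibitor), compound 1 (`Cc1ccc(/C=C/C(=O)Oc2ccc(/C=C3\CCCCC3=O)cc2)cc1`) shows > 50000 nM as its reading, which is a limit of the assay and not a number. Going by the values given here, compound 2 (`Cc1ccc(/C=C/C(=O)Oc2ccc(/C=C3\CCCC(CN(C)C)C3=O)cc2)cc1`) gives 1290 nM as the only true number so far. Among the compounds with values here, the one measured step is an at least 38-fold lower number from compound 1 to compound 2 (1.58 log units; beyond the scatter) with (dimethylamino)methyl in place of hydrogen on a saturated ring carbon. Compound 3 (`CN(C)CC1CCC/C(=C\c2ccc(OC(=O)/C=C/c3ccc(F)cc3)cc2)C1=O`) keeps that group and changes elsewhere: fluoro in place of methyl on an aromatic carbon puts fluoro in place of methyl on an aromatic carbon, para to a large group. The measured step lies at another place, so it does not speak to this swap directly. Compound 2 at 1290 nM is therefore the starting point, and no shift beyond the usual scatter is expected. The estimated change is a 1.1-fold lower number from compound 2 to compound 3 (0.03 log units; within the scatter) in this reading. Compound 3 is expected near 1200 nM with an estimated range of 420 nM to 3600 nM for this measurement.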

Compound 3, half-maximal inhibitory concentration: 4550 nM
For compound 3 the middle estimate is 3.8-fold (0.58 log units) below the measured one; measured number above the stated range.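

In this assay, the aromatic carbon para to a large group now has a measured step of its own, with fluoro in place of methyl: a 3.5-fold higher number from compound 2 to compound 3 (0.55 log units; beyond the scatter). Going by these compounds alone, until now the only step lay at a saturated ring carbon, where the change was larger: an at least 38-fold lower number from compound 1 to compound 2 (1.58 log units; beyond the scatter). So the number responds to this small swap on the aromatic ring as well, but the values shown offer no measurement that says why.

From the compounds shown here alone, whether the rise belongs to fluoro itself or to the loss of methyl stays open, and a plain hydrogen, a chlorine atom or a methoxy group on the same carbon would help separate the two. This is also a single pair of compounds in a single assay, so it does not yet make a pattern.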